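This account rests on a few compounds, and the source may have more. Where it says the series, first, only, none or still open, it means among the compounds named here.

Compound 2 `CC1(C)c2[nH]nc(NC(=O)c3ccccc3)c2CN1Cc1cc(F)cc(F)c1` gives 190 nM in an assay on Sf21 cells for inhibition of high affinity nerve growth factor receptor (Homo sapiens), read by HTRF, with a stated time of 30 min, in the presence of a further agent that is not named here (a higher number here means a weaker inhibitor, a lower number a stronger inhibitor), the lowest of the three numbers measured. Compound 1 `CC1(C)c2[nH]nc(NC(=O)c3ccccc3)c2CN1Cc1cccc(Cl)c1` gives 670 nM and compound 3 `Cc1ccc(CN2Cc3c(NC(=O)c4ccccc4)n[nH]c3C2(C)C)cc1F` gives 940 nM; the steps of a 3.5-fold lower number from compound 1 to compound 2 (0.55 log units; beyond the scatter) and a 4.9-fold higher number from compound 2 to compound 3 (0.69 log units; beyond the scatter) set compound 2 apart from both, while a 1.4-fold higher number from compound 1 to compound 3 (0.15 log units; within the scatter) stays within the scatter. Compound 4 `CN(C)c1cccc(C(=O)Nc2n[nH]c3c2CN(Cc2cc(F)cc(F)c2)C3(C)C)c1` differs from compound 2 by dimethylamino in place of hydrogen on an aromatic carbon, on an aromatic carbon of a six-membered aromatic ring of carbon only. Every measured step instead alters the group on a saturated chain carbon bound to an amine nitrogen in a ring, so none bears on this change. For compound 4 the expected step is therefore no change at the digits printed from compound 2 to compound 4 (within the scatter), nothing beyond the scatter. Compound 4 is estimated at 190 nM, with a range from 70 nM to 500 nM.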

Compound 4, half-maximal inhibitory concentration: 270 nM
The estimate for compound 4 lay 1.4-fold (0.15 log units) below the measured number; low and high end bracket the measured number.
By their numbers in this assay, from the lowest: compounds 2 and 4 (each within the scatter of the next); then compounds 1 and 3 (each within the scatter of the next).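

Placing dimethylamino on an aromatic carbon of a six-membered aromatic ring of carbon only, phenyl to 3-(dimethylamino)phenyl, gives in this assay a 1.4-fold higher number from compound 2 to compound 4 (0.15 log units; within the scatter). Going by these compounds alone, this ring stayed the same in the earlier compounds, and the result shows that it can carry dimethylamino with no change beyond the scatter. Nothing available accounts for this outcome.

From the compounds shown here alone, whether a carboxylic acid or morpholine would behave the same way on this ring remains open. So does whether dimethylamino would give the same result alongside the 3-chlorophenyl group of compound 1.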